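From formyl to 2-(ethoxycarbonyl)ethenyl at the assay limit

This account rests on a few compounds, and the source may have more. Where it says the series, first, only, none or still open, it means among the compounds named here.

Compound 1 (`C=C[C@@](C)(/C=C/c1ccc(O)cc1)CCCO`) gives > 36600 nM in a functional assay on SEM cells (Homo sapiens) for cytotoxicity, with a stated time of 72 h (a lower number here means that less compound is needed, a higher number that more compound is needed for the effect), as a limit only. Compound 2 (`C=C[C@@](C)(/C=C/c1ccc(O)cc1)CC/C=C/C#N`) gives > 36600 nM as a limit too. Compound 3 (`C=C[C@@](C)(/C=C/c1ccc(O)cc1)CC/C=C(\C)C=O`) gives > 36600 nM as a limit as well. Among the measured compounds shown here, the series so far rests on the limit of > 36600 nM in this assay, at which 3 of the 3 values shown sit, and holds no number.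

Compound 4 (`C=C[C@@](C)(/C=C/c1ccc(O)cc1)CC/C=C(C)/C=C/C(=O)OCC`) carries 2-(ethoxycarbonyl)ethenyl in place of formyl on a double-bonded chain carbon bound to a double-bonded chain carbon and a saturated chain carbon. The measured changes nearest to it are a step that the two limits leave unreadable from compound 1 to compound 3 and a step that the two limits leave unreadable from compound 2 to compound 3 and neither has a size to carry over. No step beyond the scatter is therefore expected, in either direction. The expected change is an at least 1.0-fold lower number from compound 3 to compound 4 (0.00 log units; that floor lies within the scatter) and it remains an estimate. For compound 4 the estimated value is 36000 nM within an expected range of 15000 nM to 70000 nM and another limit is the likeliest report.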

Compound 4, half-maximal effective concentration: > 36600 nM
Compound 4: no number, only a limit; the forecaster's own chance of this, stated with the estimate: 70%; middle value at least 1.0-fold (0.00 log units) from the limit.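

Compound 3 and compound 4 both stand only as limits in this assay, so no step between them can be read: the limit of > 36600 nM in this assay, at which 4 of the 4 values shown sit.

The compounds shown leave open what number any of them would give and whether changing this chain moves it at all.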